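A few compounds are considered here, and "the series" means these few. Any claim that something is new, unique, unknown or untested is made for them only; others in the source may bear on it.

Measured in a functional assay on SEM cells (Homo sapiens) for cytotoxicity, with a stated time of 72 h; a lower number here means that less compound is needed, a higher number that more compound is needed for the effect:
Compound 1 `C=C[C@@](C)(/C=C/c1ccc(O)c(C=O)c1)CCC=C(C)C`: 8510 nM
Compound 2 `C=C[C@@](C)(/C=C/c1ccc(O)c(/C=C/C(=O)OCC)c1)CCC=C(C)C`: > 36600 nM, a limit and not a number

Compound 2 stands at the limit of > 36600 nM in this assay, at which 1 of the 2 values shown sits. Compound 3 `C=C[C@@](C)(/C=C/c1ccc(O)c(/C=C(\C)C(=O)OCC)c1)CCC=C(C)C` differs from it in one place: 2-(ethoxycarbonyl)prop-1-en-1-yl in place of 2-(ethoxycarbonyl)ethenyl on an aromatic carbon. Going by the values given here, the only measured step at this place is an at least 4.3-fold higher number from compound 1 to compound 2 (0.63 log units; beyond the scatter). That step replaced a formyl group, so it does not cover the present exchange. Among the compounds with values here, no measured step does, so no step beyond the scatter is expected in this assay, and another limit may well be reported. The expected size of the change is a step that the limit leaves unreadable from compound 2 to compound 3. For compound 3 the estimate is 40000 nM, with an expected range of 18000 nM to 80000 nM.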

Compound 3, half-maximal effective concentration: > 36600 nM
Compound 3: no number, only a limit; the forecaster's own chance of this, stated with the estimate: 65%; the middle value does not contradict the limit.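

A second ester-bearing group on this aromatic carbon, ortho to the hydroxy group, now gives the same kind of result when it replaces formyl: an at least 4.3-fold higher number from compound 1 to compound 3 (0.63 log units; beyond the scatter) in this assay. Compound 3 gives > 36600 nM, which is a limit and not a number. The step between compound 2 and compound 3 cannot be read because both sit at that limit: the limit of > 36600 nM in this assay, at which 2 of the 3 values shown sit.

Going by these compounds, whether the extra carbon of 2-(ethoxycarbonyl)prop-1-en-1-yl changes anything therefore stays open. Also open, on these data alone, is how a carboxylic acid in place of the ethyl ester would read in this assay.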